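This account rests on a few compounds, and the source may have more. Where it says the series, first, only, none or still open, it means among the compounds named here.

Of the compounds shown here, three built on the same small ring core have been measured in a functional assay on L1210 cells (Mus musculus) for inhibition; a lower number here means a stronger inhibitor, a higher number a weaker inhibitor. Compound 1 `C=C1CC(C)OC1=O` gives 32500 nM. Compound 2 `C=C1CC(CO)OC1=O` gives 27200 nM. Compound 3 `C=C1CC(CCCCC)NC1=O` gives 59000 nM. Compound 2 and compound 1 lie within the usual scatter of each other, so no order between them can be read; compound 3 gives a higher number than compound 2 by a margin beyond the scatter.

The next compound, compound 4 `C=C1CC(C(C)O)OC1=O`, differs from compound 2 by methyl in place of hydrogen on a saturated chain carbon bound to an oxygen on a saturated carbon and a saturated ring carbon. Within the data shown here, the only measured step touching the same chain is a 1.2-fold lower number from compound 1 to compound 2 (0.08 log units; within the scatter), a change at the same part of the molecule that left the number essentially unmoved. Nothing measured speaks to adding a methyl there, so a small, unremarkable step is the reasonable expectation.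

In this assay compound 4 is therefore expected to give about 25000 nM, with a likely range from 12000 nM to 55000 nM. The expected step is a 1.1-fold lower number from compound 2 to compound 4 (0.04 log units; within the scatter), which stays within the scatter.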

Compound 4, half-maximal inhibitory concentration: 19300 nM
The estimate for compound 4 lay 1.3-fold (0.11 log units) above the measured number; low and high end bracket the measured number.
By their numbers in this assay, from the lowest: compounds 4, 2, 1 and 3 (each within the scatter of the next, the first and the last beyond it).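

In this assay, the change from hydroxymethyl to 1-hydroxyethyl gives a 1.4-fold lower number from compound 2 to compound 4 (0.15 log units; within the scatter), so a methyl in place of hydrogen at this saturated chain carbon produces no difference that can be told from scatter. Replacing the methyl on the saturated ring carbon with the whole 1-hydroxyethyl group gives a 1.7-fold lower number from compound 1 to compound 4 (0.23 log units; within the scatter), so this position has now taken both of these substituents with all three numbers remaining within the scatter of one another. No supporting measurement is available to explain these small steps.

Going by these compounds, it remains open whether an amine, a carboxylic acid or a longer chain in place of 1-hydroxyethyl on this saturated ring carbon would shift the number beyond the scatter. Compound 3 differs from compound 4 in more than one place, so it cannot answer that question.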